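The source may report more compounds than this note shows. Statements on the series, on what has been measured and on what is new or still open speak of the compounds shown alone.

Measured compounds:
- compound 1, `CC(=O)OCC(CCn1cc(C#Cc2ccc(Br)cc2)c(=O)n(C(=O)c2ccccc2)c1=O)COC(C)=O`: in a functional assay on SW-620 cells (Homo sapiens) for antiproliferative activity, read by MTT assay, with a stated time of 72 h (a higher number here means a weaker inhibitor, a lower number a stronger inhibitor), compound 1 gives > 100000 nM
- compound 2, `O=c1[nH]c(=O)n(CCC(CO)CO)cc1C#CCc1ccccc1`: in this assay compound 2 gives 72400 nM

The value shown for compound 1 is a limit of the assay, not a number, so compound 1 has no measured potency here; it sits at the limit of > 100000 nM in this assay, at which 1 of the 2 values shown sits. Within the data shown here, compound 2 therefore holds the only real number in this set, and nothing else measured stands above or below it for comparison.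

Compound 3, `CCCCCCCCC#Cc1cn(CCC(CO)CO)c(=O)[nH]c1=O`, is the unmeasured compound. It differs from compound 2 in one place: heptyl in place of phenyl on a saturated chain carbon bound to a triple-bonded carbon. Put simply, the flat aromatic ring at the end of the chain is swapped for a straight saturated chain of similar length, while the rest of compound 2 is kept.

Among the measured compounds shown here, no step between two measured compounds covers a change like this, so there is no measured precedent to lean on. The step from compound 2 to compound 3 in this assay is expected to be small, a 1.2-fold lower number from compound 2 to compound 3 (0.08 log units; within the scatter), with no clear direction beyond the usual scatter. Compound 3 is expected to give about 60000 nM, between 15000 nM and 150000 nM.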

Compound 3, half-maximal inhibitory concentration: > 100000 nM
Compound 3: only a limit was reported; the forecaster's own chance of this, stated with the estimate: 35%; at least 1.6-fold (0.22 log units) between middle value and limit.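

In this assay compound 3 gives > 100000 nM, which is a limit of the assay and not a number. Putting heptyl in place of phenyl on a saturated chain carbon bound to a triple-bonded carbon gives an at least 1.3-fold higher number from compound 2 to compound 3 (0.14 log units; that floor lies within the scatter), so this change has only a lower bound on its size, and that bound does not clear the usual scatter. The new information is that this position now has a second group, heptyl, but it yields no measured potency, so compound 2 still holds the only real number in the set, and the limit accounts for most of the values: the limit of > 100000 nM in this assay, at which 2 of the 3 values shown sit.

As far as these compounds go, the true size of the step remains unknown, and the data cannot tell whether the loss of the aromatic ring or the nature of the chain matters more here. Also open, from the compounds shown here alone, is how a shorter chain such as butyl, or an amine or a carboxylic acid in the same place, would read in this assay.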